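Amide aryl variation on the shared core: compound 4

The source may hold more compounds than are shown below. What is called first, only, known or untested is meant among the compounds shown, and "the series" means these compounds.

Three amides of the shared core have been measured in a functional assay on MDA-MB-231 cells (Homo sapiens) for antiproliferative activity, read by CCK-8 assay, with a stated time of 72 h; a higher number here means a weaker inhibitor, a lower number a stronger inhibitor. Compound 1 `Cc1ccc(C(=O)Nc2cccc(-c3oc4cc(-c5ccc(F)cc5)ccc4c(=O)c3O)c2)cc1` gives 4350 nM. Compound 2 `COc1cccc(C(=O)Nc2cccc(-c3oc4cc(-c5ccc(F)cc5)ccc4c(=O)c3O)c2)c1` gives 9160 nM. Compound 3 `Cc1cc(C)cc(C(=O)Nc2cccc(-c3oc4cc(-c5ccc(F)cc5)ccc4c(=O)c3O)c2)c1` gives 11900 nM. Compound 2 stands second highest of the three numbers: it differs from compound 1 by a 2.1-fold higher number from compound 1 to compound 2 (0.32 log units; beyond the scatter), while the pair of compound 2 and compound 3 shows only a 1.3-fold higher number from compound 2 to compound 3 (0.11 log units; within the scatter). The remaining step is a 2.7-fold higher number from compound 1 to compound 3 (0.44 log units; beyond the scatter).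

Compound 4 `O=C(Nc1cccc(-c2oc3cc(-c4ccc(F)cc4)ccc3c(=O)c2O)c1)c1ccc(-c2ccccc2)cc1` is not yet measured. Its change from compound 2 is 4-phenylphenyl in place of 3-methoxyphenyl on a carbonyl carbon. For the measured compounds named here, no measured step adds a second aromatic ring, so the bearing of the existing steps is indirect: both departures from the 4-methylphenyl of compound 1 gave modest weakening, and compound 4 returns to a 4-substituted ring pattern, though with a far larger group than any measured. The step of a 1.7-fold lower number from compound 2 to compound 4 (0.22 log units; within the scatter) is therefore expected to be modest, toward a lower number, with wide uncertainty. Compound 4 is estimated at 5500 nM in this assay, within 1800 nM to 17000 nM.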

Compound 4, half-maximal inhibitory concentration: 63200 nM
The estimate for compound 4 lay 11-fold (1.06 log units) below the measured number, and the stated range ends below it.
By their numbers in this assay, from the lowest: compound 1; then compounds 2 and 3 (each within the scatter of the next); then compound 4.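

In this assay, the three single-ring amides span a narrow range, and the 4-phenylphenyl group falls clearly outside it: a 6.9-fold higher number from compound 2 to compound 4 (0.84 log units; beyond the scatter), and a 5.3-fold higher number from compound 3 to compound 4 (0.73 log units; beyond the scatter). The clearest reading comes from phenyl in place of methyl on an aromatic carbon, a 15-fold higher number from compound 1 to compound 4 (1.16 log units; beyond the scatter), which shows that a 4-substituted ring does not by itself keep the number low and that the group carried there counts. Nothing at hand explains this loss.

On these data alone, it remains open whether the loss belongs to the second aromatic ring itself or would come with any larger group on that carbon. A 4-cyclohexylphenyl, a 4-ethylphenyl or a 4-aminophenyl amide would help separate these readings, and a pyridine in place of the outer phenyl would test the ring's carbon-only makeup.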